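This account rests on a few compounds, and the source may have more. Where it says the series, first, only, none or still open, it means among the compounds named here.

Values in an assay on isolated protein for binding affinity to leukotriene B4 receptor 1 (Homo sapiens), tested at 1 uM; a higher number here means more inhibition at the concentration tested (going by the name of the read-out), a lower number less inhibition:

compound 1 `CCc1cc(C(C)=O)c(O)cc1OCCCCCCC#N`: 73%
compound 2 `CCc1cc(C(C)=O)c(O)cc1OCCCC(C)(C)C#N`: 46%
compound 3 `CCc1cc(C(C)=O)c(O)cc1OCCCC(C)(C)C(=O)O`: 43%

Compound 3 holds the lowest of the three numbers. Its nearest neighbour is compound 2, the gap being a number 3 percentage points lower from compound 2 to compound 3 (within the scatter) and so within the scatter; the furthest is compound 1, with a number 30 percentage points lower from compound 1 to compound 3 (beyond the scatter). The other step of the set, a number 27 percentage points lower from compound 1 to compound 2 (beyond the scatter), shows that shortening and branching the chain costs a modest amount, while exchanging cyano for carboxy at the branched chain carbon costs nothing measurable.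

Compound 4 `CCc1cc(C(C)=O)c(O)cc1OCCCC(C)(C)c1nnn[nH]1` is the next member to be measured. It differs from compound 3 as follows: 1H-tetrazol-5-yl in place of carboxy on a saturated chain carbon bound to three saturated chain carbons

Within the data shown here, the step that bears on this is the one from compound 2 to compound 3, where one terminal group replaced another at the same branched carbon with no change beyond the scatter. On that basis compound 4 is expected to sit close to compound 3, with an estimated step of a number 2 percentage points higher from compound 3 to compound 4 (within the scatter). The estimated value for compound 4 in this assay is 45%, within the range 28% to 62%.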

Compound 4, a percentage reported as inhibition, at one concentration (the size of the read-out at that concentration, not a potency): 76%
Beside the measured number, compound 4's estimate is 31 percentage points below it; measured number outside the range, above it.
By their numbers in this assay, from the lowest: compounds 3 and 2 (each within the scatter of the next); then compounds 1 and 4 (each within the scatter of the next).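

At the saturated chain carbon bound to three saturated chain carbons, the terminal group matters in this assay: 1H-tetrazol-5-yl in place of carboxy gives a number 33 percentage points higher from compound 3 to compound 4 (beyond the scatter), and in place of cyano it gives a number 30 percentage points higher from compound 2 to compound 4 (beyond the scatter), although the exchange of cyano for carboxy alone had left the number unmoved. The loss seen with the cyano and carboxy ends therefore does not follow from the shorter, branched chain alone, since 1-(1H-tetrazol-5-yl)-1-methylethyl in place of 3-cyanopropyl gives a number 3 percentage points higher from compound 1 to compound 4 (within the scatter). Nothing available explains why 1H-tetrazol-5-yl separates from carboxy here.

Still open, on these data alone, is how 1H-tetrazol-5-yl behaves at the end of an unbranched chain or a longer chain. Also open, as far as these compounds go, is whether an amide or a sulfonamide at the same branched carbon would read like 1H-tetrazol-5-yl or like carboxy.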